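The compounds below may be only part of what the source reports. "The series", "measured", "known", "first", "only" and "open" are said of these compounds alone.

The account follows compound 1 `CCOC(=O)c1ccc2oc(N3CCN(C)CC3)nc2c1` in a functional assay on ileum (strain Hartley) for agonist activity at 5-hydroxytryptamine receptor 3A (Cavia porcellus); on this read-out lower numbers stand for lower potency and higher numbers for higher potency (the scale is a negative logarithm). In this assay compound 1 gives only a limit, < 4, and not a measured number. Compound 2 `COc1cccc2nc(N3CCN(C)CC3)oc12` likewise returns a limit in this assay, < 4. Going by the values given here, compound 1 therefore stands at the limit of < 4 in this assay, at which 2 of the 2 values shown sit, and no measured step between the two compounds is available to compare against. Compound 3 `CN1CCN(c2nc3cc(C(F)(F)F)ccc3o2)CC1` carries trifluoromethyl in place of ethoxycarbonyl on an aromatic carbon. With both known values sitting at the limit, no change beyond the usual scatter is expected, and the expected step is a step that the limit leaves unreadable from compound 1 to compound 3. Compound 3 is thus estimated at 3.8 in this assay, between 3.3 and 4.5.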

Compound 3, negative logarithm of the half-maximal effective concentration: < 4
Compound 3 was reported as a limit; the forecaster's own chance of this, stated with the estimate: 70%; the middle value is on the limit's open side.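

Compound 1 and compound 3 both give only limits, so no step between them can be read in this assay: the limit of < 4 in this assay, at which 3 of the 3 values shown sit.

The compounds shown leave open what potency any of them actually has, and whether trifluoromethyl in place of ethoxycarbonyl changes it.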